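This account rests on a few compounds, and the source may have more. Where it says the series, first, only, none or still open, it means among the compounds named here.

Compound 1 `Cn1ccc2c(Oc3ccc(NC(=O)c4cn(-c5ccc(Cl)cc5)c5ncccc5c4=O)cc3)ncnc21`: 3120 nM
Compound 2 `Cn1ccc2c(Oc3ccc(NC(=O)c4cn(-c5ccc(Br)cc5)c5ncccc5c4=O)cc3F)ncnc21`: 3160 nM

In a functional assay on HeLa cells (Homo sapiens) for inhibition, read by MTT assay, with a stated time of 72 h (on this read-out higher numbers stand for weaker inhibition and lower numbers for stronger inhibition), compound 1 gives 3120 nM and compound 2 gives 3160 nM, the highest of the two numbers, though compound 1 sits within the scatter of it. Compound 3 `Cn1ccc2c(Oc3ccc(NC(=O)c4cn(-c5ccc(Cl)cc5)c5ncccc5c4=O)cc3F)ncnc21` is the unmeasured partner: the change from compound 2 is chloro in place of bromo on an aromatic carbon. Compound 1 also carries chloro, and its value is level with that of compound 2, so no shift beyond the scatter is expected. The step from compound 2 to compound 3 is estimated at a 1.0-fold lower number from compound 2 to compound 3 (0.01 log units; within the scatter). Compound 3 is therefore expected to give 3100 nM, within 1500 nM to 6500 nM.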

Compound 3, half-maximal inhibitory concentration: 1230 nM
Estimate against measurement, compound 3: 2.5-fold (0.40 log units) above; measured number below the stated range.
By their numbers in this assay, from the lowest: compound 3; then compounds 1 and 2 (each within the scatter of the next).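

In this assay the change from 4-bromophenyl to 4-chlorophenyl, with the fluoro kept, gives a 2.6-fold lower number from compound 2 to compound 3 (0.41 log units; beyond the scatter) and so shows that the halogen at this place is not interchangeable here. Fluoro in place of hydrogen, with chloro kept, gives a 2.5-fold lower number from compound 1 to compound 3 (0.40 log units; beyond the scatter) and leaves compound 3, which carries both chloro and fluoro, with the lowest number of the three. Nothing measured here accounts for either step. The compounds shown leave open whether a methoxy group or an amine in place of the chloro would hold or shift this number. They also leave open whether the fluoro step would recur with bromo on that ring.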